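A few compounds are considered here, and "the series" means these few. Any claim that something is new, unique, unknown or untested is made for them only; others in the source may bear on it.

In an ADME assay on Vero cells (Chlorocebus sabaeus) for cytotoxicity, read by MTT assay, with a stated time of 72 h (on this read-out lower numbers stand for higher toxicity in this test and higher numbers for lower toxicity in this test), compound 3 `COc1c(N2CCN(C/C(C)=N/O)C(C)C2)c(F)cc2c(=O)c(C(=O)O)cn(C3CC3)c12` stands in the middle of the three measured numbers at 177 ug/mL, with compound 1 `COc1c(N2CCN(CC(C)=O)C(C)C2)c(F)cc2c(=O)c(C(=O)O)cn(C3CC3)c12` higher at 500 ug/mL and compound 2 `CO/N=C(\C)CN1CCN(c2c(F)cc3c(=O)c(C(=O)O)cn(C4CC4)c3c2OC)CC1C` lower at 49.6 ug/mL.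

Compound 4 `CO/N=C(\C)CCN1CCN(c2c(F)cc3c(=O)c(C(=O)O)cn(C4CC4)c3c2OC)CC1C` differs from compound 3 by a group of 6 heavy atoms (4 carbon, 1 nitrogen, 1 oxygen; no ring) in place of a group of 4 heavy atoms (2 carbon, 1 nitrogen, 1 oxygen; no ring), on a saturated chain carbon bound to an amine nitrogen in a ring.

For the measured compounds named here, three measured steps bear on this change. Two of them replace the group at the same place with a larger one, and both lead to lower numbers: a 2.8-fold lower number from compound 1 to compound 3 (0.45 log units; beyond the scatter) and a 10-fold lower number from compound 1 to compound 2 (1.00 log units; beyond the scatter). Among these three compounds, none goes against that trend. The third step is a 3.6-fold higher number from compound 2 to compound 3 (0.55 log units; beyond the scatter), with hydrogen in place of methyl on an oxygen. Compound 4 has methyl on that oxygen, so this step applies in the opposite direction and also points to a lower number. Going by the values given here, no measured compound carries the entering group itself, so the size of its contribution remains uncertain.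

A modest fall beyond the scatter is therefore expected, with an estimated 5.1-fold lower number from compound 3 to compound 4 (0.70 log units; beyond the scatter). Compound 4 is expected to give about 35 ug/mL, with an estimated range of 12 ug/mL to 100 ug/mL.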

Compound 4, half-maximal cytotoxic concentration: 157 ug/mL
For compound 4 the middle estimate is 4.5-fold (0.65 log units) below the measured one; the measured number lies above the stated range.
By their numbers in this assay, from the lowest: compound 2; then compounds 4 and 3 (each within the scatter of the next); then compound 1.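

In this assay, growth of the group on a saturated chain carbon bound to an amine nitrogen in a ring does not bring a steady fall: the group of 6 heavy atoms gives a 1.1-fold lower number from compound 3 to compound 4 (0.05 log units; within the scatter) and also a 3.2-fold higher number from compound 2 to compound 4 (0.50 log units; beyond the scatter), so compound 2, with its group of 5 heavy atoms, goes against any trend with heavy-atom count across compounds 2, 3 and 4. The ketone-bearing group of compound 1 remains apart, with a 3.2-fold lower number from compound 1 to compound 4 (0.50 log units; beyond the scatter), and compounds 2, 3 and 4 all give lower numbers than compound 1, with none of the three going against that. No supporting measurement accounts for the order of these numbers.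

The compounds shown do not separate the longer chain from methyl on the oxygen, a question that the longer group with hydrogen on that oxygen would address. On these data alone, it also remains open how this assay responds to a still longer chain, or to an amine or a carboxylic acid at this place.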